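The compounds below may be only part of what the source reports. "The series", "measured", "known", "first", "only" and "open" are said of these compounds alone.

In an assay on HEK293 cells for displacement of a labelled ligand from metabotropic glutamate receptor 5 (Homo sapiens), with a stated time of 2 h (on this read-out lower numbers stand for stronger inhibition and higher numbers for weaker inhibition), compound 2 `O=C1c2ccc(C#Cc3ccccc3)nc2CCN1C1CCCCC1` gives 12400 nM, the highest of the two numbers in hand. Among the compounds with values here, compound 1 `Cc1cccc(C#Cc2ccc3c(n2)CCN(C(C)C)C3=O)c1` gives 510 nM, a lower number, yet compound 1 and compound 2 differ at two places, so no single measured step connects them. Compound 3 `Cc1cccc(C#Cc2ccc3c(n2)CCN(C2CCCCC2)C3=O)c1` carries the change (methyl in place of hydrogen on an aromatic carbon), methyl in place of hydrogen on an aromatic carbon, while keeping the cyclohexyl of compound 2. A step toward lower numbers is expected, a 4.1-fold lower number from compound 2 to compound 3 (0.62 log units; beyond the scatter), of uncertain size, because the methyl is the group that compound 1 carries at 510 nM. Compound 3 is estimated at 3000 nM, within 800 nM to 12000 nM.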

Compound 3, inhibition constant: 3210 nM
Compound 3: the middle estimate sits 1.1-fold (0.03 log units) below what was measured; measured number inside the range.
By their numbers in this assay, from the lowest: compound 1; then compound 3; then compound 2.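

In this assay the change from phenyl to 3-methylphenyl gives a 3.9-fold lower number from compound 2 to compound 3 (0.59 log units; beyond the scatter) and so stands as a single measured step with cyclohexyl on the amide-type nitrogen. Cyclohexyl in place of isopropyl on that nitrogen, with 3-methylphenyl held, gives a 6.3-fold higher number from compound 1 to compound 3 (0.80 log units; beyond the scatter) and so shows that this second place also moves the number. Nothing in hand accounts for either step.
Open, as far as these compounds go, is whether a methoxy group or a chlorine at the methyl's place would go beyond the methyl. Also open, from the compounds shown here alone, is how a cyclopropyl group or a hydrogen would read on the nitrogen.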